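Fluoro for Chloro: Expected Half-Life of Compound 3

A few compounds are considered here, and "the series" means these few. Any claim that something is new, unique, unknown or untested is made for them only; others in the source may bear on it.

compound 1 `CN1CCC(=C(F)c2cccc(NC(=O)c3ccc(F)cn3)n2)CC1`: 1.24 h
compound 2 `CN1CCC(=C(F)c2cccc(NC(=O)c3ccc(Cl)cc3)n2)CC1`: 2.41 h

Within the data shown here, in an ADME assay on the whole organism (Rattus norvegicus, strain Sprague-Dawley) for metabolic stability, read by LC-MS, with a stated time of 24 h, at a dose of 5 mg/kg by the oral route (a higher number here means that the compound lasts longer, a lower number that the compound disappears faster), compound 2 holds the higher of the two numbers, yet the only measured step, a 1.9-fold higher number from compound 1 to compound 2 (0.29 log units; within the scatter), stays within the scatter. Compound 3 `CN1CCC(=C(F)c2cccc(NC(=O)c3ccc(F)cc3)n2)CC1` differs from compound 2 by fluoro in place of chloro on an aromatic carbon. Among the measured compounds shown here, no measured step isolates this halogen swap; the step from compound 1 to compound 2 changes ring and halogen together and is itself within the scatter. The expected step of a 1.2-fold lower number from compound 2 to compound 3 (0.08 log units; within the scatter) is therefore none beyond the scatter. Compound 3 is estimated at 2 h, between 1 h and 4 h.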

Compound 3, half-life: 1.41 h
Estimate against measurement, compound 3: 1.4-fold (0.15 log units) above, and the stated range covers the measured number.
By their numbers in this assay, from the lowest: compounds 1, 3 and 2 (each within the scatter of the next).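

In this assay, the halogen on an aromatic carbon, para to a large group, can now be read alone (a 1.7-fold lower number from compound 2 to compound 3 (0.23 log units; within the scatter)), and this swap of chloro for fluoro stays within the scatter. The ring can also be read alone with fluorine held in the compared groups (a 1.1-fold higher number from compound 1 to compound 3 (0.06 log units; within the scatter)), and this change of 5-fluoropyridin-2-yl to 4-fluorophenyl also stays within the scatter. Nothing available explains either step. The compounds shown leave open whether a non-halogen group at this place, such as an amine or a methoxy group, would shift the half-life beyond the scatter.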